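A Crotonyl-Like Group on the Nitrogen of Compound 3

A few compounds are considered here, and "the series" means these few. Any claim that something is new, unique, unknown or untested is made for them only; others in the source may bear on it.

Measured in a functional assay on MGC-803 cells (Homo sapiens) for inhibition, read by MTT assay, with a stated time of 48 h; a higher number here means a weaker inhibitor, a lower number a stronger inhibitor:
Compound 1 (`COc1cc(NCc2ccc(Cl)cc2)cc(OC)c1OC`) gives > 80000 nM (a limit)
Compound 2 (`COc1cc(NCc2ccc(Br)cc2)cc(OC)c1OC`) gives > 80000 nM (a limit)
Compound 3 (`COc1cc(NCc2cccc(O)c2)cc(OC)c1OC`) gives 57600 nM

Compound 3 is the only one of the three with a number, 57600 nM. Compound 1 and compound 2 both stand at the limit of > 80000 nM in this assay, at which 2 of the 3 values shown sit. Between those two, with bromo in place of chloro, there is a step that the two limits leave unreadable from compound 1 to compound 2. The two steps that reach the 3-hydroxyphenyl group are an at least 1.3-fold lower number from compound 1 to compound 3 (0.14 log units; that floor lies within the scatter) and an at least 1.3-fold lower number from compound 2 to compound 3 (0.14 log units; that floor lies within the scatter). Both alter the aromatic group on the saturated chain carbon, and neither touches the nitrogen.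

Compound 4 (`C/C=C/C(=O)N(Cc1cccc(O)c1)c1cc(OC)c(OC)c(OC)c1`) carries one change from compound 3: (prop-1-en-1-yl)carbonyl in place of hydrogen on a nitrogen on an aromatic ring. Going by the values given here, no measured step alters that nitrogen, so none of them sizes this change directly. The expected step, an estimate, is a 3.8-fold lower number from compound 3 to compound 4 (0.58 log units; beyond the scatter), toward a lower number in this assay. That expectation rests only on compound 3 at 57600 nM and on the structural change itself, so it is loose and the range is kept wide. For compound 4 the estimated value is 15000 nM, within an expected range of 3000 nM to 70000 nM.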

Compound 4, half-maximal inhibitory concentration: 14100 nM
The estimate for compound 4 lay 1.1-fold (0.03 log units) above the measured number; the measured number falls inside the stated range.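

In this assay, going by these compounds alone, (prop-1-en-1-yl)carbonyl in place of hydrogen on the nitrogen gives a 4.1-fold lower number from compound 3 to compound 4 (0.61 log units; beyond the scatter), so this position, which no earlier step touched, can carry an acyl group in place of its hydrogen without loss of activity. The earlier steps changed only the aromatic group on the saturated chain carbon, and their floors lay within the scatter; this is the first step here with two real numbers at its ends and a size beyond the scatter, which makes the nitrogen the one place shown where a change clearly moves the result. Compound 1 and compound 2 stay at a limit rather than a number, so they cannot show whether the same change would act on them: the limit of > 80000 nM in this assay, at which 2 of the 4 values shown sit.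

The compounds shown leave open which part of the entering group carries the step, the carbonyl alone or the carbonyl with its double bond; an acetyl or a saturated butanoyl group on the same nitrogen would separate the two. They also leave open whether the step holds with the 4-chlorophenyl or 4-bromophenyl group in place of 3-hydroxyphenyl.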